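The source may report more compounds than this note shows. Statements on the series, on what has been measured and on what is new or still open speak of the compounds shown alone.

Three compounds share one core and differ in a single group on its six-membered aromatic ring with one nitrogen. Compound 1 `CN1CCC[C@H]1COc1cncc(C(F)(F)F)c1` carries a trifluoromethyl there, and in an assay on membranes from brain for displacement of a labelled ligand from Neuronal acetylcholine receptor; alpha4/beta2 (Rattus norvegicus) (a lower number here means a stronger inhibitor, a higher number a weaker inhibitor), compound 1 gives 1.83 nM. Compound 2 `CCc1cncc(OC[C@@H]2CCCN2C)c1` carries an ethyl and gives 0.32 nM. Compound 3 `CCCCCCc1cncc(OC[C@@H]2CCCN2C)c1` carries a hexyl and gives 0.32 nM. Compound 3 thus sits level with compound 2 at the digits shown, and the two together hold the lowest numbers of the three, with compound 1 furthest away: a 5.7-fold lower number from compound 1 to compound 3 (0.76 log units; beyond the scatter). Compound 2 and compound 3 lie within the scatter of each other: no change at the digits printed from compound 2 to compound 3 (within the scatter).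

Compound 4 `COC(=O)c1cncc(OC[C@@H]2CCCN2C)c1` takes the next step: methoxycarbonyl in place of hexyl on an aromatic carbon. Two kinds of measured step bear on it. a 5.7-fold lower number from compound 1 to compound 3 (0.76 log units; beyond the scatter) and a 5.7-fold lower number from compound 1 to compound 2 (0.76 log units; beyond the scatter) show that ethyl and hexyl each gave a modest improvement over trifluoromethyl, while no change at the digits printed from compound 2 to compound 3 (within the scatter) shows that the short and the long chain gave the same number. A methoxycarbonyl, with its 2 hydrogen-bond acceptors, is neither a chain nor a trifluoromethyl, so none of these steps speaks for it directly. With no direct guide, a modest move upward is expected, a 4.7-fold higher number from compound 3 to compound 4 (0.67 log units; beyond the scatter). Compound 4 is therefore estimated at 1.5 nM in this assay, with a range from 0.3 nM to 8 nM.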

Compound 4, inhibition constant: 1.45 nM
Estimate against measurement, compound 4: 1.0-fold (0.01 log units) above; the measured number falls inside the stated range.
By their numbers in this assay, from the lowest: compounds 2 and 3 (each within the scatter of the next); then compounds 4 and 1 (each within the scatter of the next).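

In this assay, this aromatic carbon, two atoms from the ring nitrogen, does not give the same number for every group: the level shared by ethyl and hexyl is lost with methoxycarbonyl, which has hydrogen-bond acceptors where the two chains have none, with a 4.5-fold higher number from compound 3 to compound 4 (0.66 log units; beyond the scatter) and a 4.5-fold higher number from compound 2 to compound 4 (0.66 log units; beyond the scatter). Methoxycarbonyl and trifluoromethyl share little in their atoms, yet they cannot be told apart here, with a 1.3-fold lower number from compound 1 to compound 4 (0.10 log units; within the scatter), so among these four compounds the numbers fall into two pairs, the chains in compounds 2 and 3 and the non-chain groups in compounds 1 and 4. Nothing available explains why the numbers split this way.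

As far as these compounds go, whether a carboxylic acid or an amide in place of the methoxycarbonyl would stay level with compound 4 or come closer to compounds 2 and 3 remains open, as does what an amine or a bare hydrogen would give on this carbon. From the compounds shown here alone, it is also open whether the match between ethyl and hexyl extends to a branched chain or a phenyl ring.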